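This account rests on a few compounds, and the source may have more. Where it says the series, first, only, none or still open, it means among the compounds named here.

Measured so far in a toxicity assay on HFF-1 cells (Homo sapiens) for cytotoxicity, read by WST assay, with a stated time of 72 h; on this read-out higher numbers stand for weaker inhibition and lower numbers for stronger inhibition:
- compound 1 `CCN(CC)CC#CCSc1nc2c(c(=O)[nH]c(=O)n2C)n1C`: 3680 nM
- compound 2 `CCN(CC)CC#CCSc1nc(SCC#CCN(CC)CC)c2c(ncn2C)n1`: 5950 nM
- compound 3 `Cn1c(SCC#CCN2CCCC2)nc2c1c(=O)[nH]c(=O)n2C`: 34300 nM

Of these three, compound 3 has the highest number, which means the weakest inhibition of the cells. Compound 2 is the nearest to it and compound 1 the furthest.

The next molecule, compound 4 `Cn1c(SCC#CCN2CCCCC2)nc2c1c(=O)[nH]c(=O)n2C`, keeps the shared core and the chain of compound 3. Among the compounds with values here, its only change is piperidin-1-yl in place of pyrrolidin-1-yl on a saturated chain carbon bound to a triple-bonded carbon.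

Within the data shown here, only one measured step changes this same place: a 9.3-fold higher number from compound 1 to compound 3 (0.97 log units; beyond the scatter), with pyrrolidin-1-yl taking the place of diethylamino. Among the measured compounds shown here, that modest step shows that the number can respond to a change here, but no measurement yet shows piperidin-1-yl on this core. Compound 2 differs in more than one place, so it offers no direct comparison. With compound 3 already highest at 34300 nM, a smaller move towards lower numbers seems the likeliest outcome in this assay, though this is a weakly supported expectation. The expected change is a 2.1-fold lower number from compound 3 to compound 4 (0.33 log units; beyond the scatter). For compound 4 the estimated value is 16000 nM, with an expected range from 5000 nM to 50000 nM.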

Compound 4, half-maximal inhibitory concentration: 30400 nM
For compound 4 the middle estimate is 1.9-fold (0.28 log units) below the measured one; the measured number falls inside the stated range.
By their numbers in this assay, from the lowest: compounds 1 and 2 (each within the scatter of the next); then compounds 4 and 3 (each within the scatter of the next).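

In this assay, going from the five-membered ring of pyrrolidin-1-yl to the six-membered ring of piperidin-1-yl on a saturated chain carbon bound to a triple-bonded carbon makes no readable difference, with a 1.1-fold lower number from compound 3 to compound 4 (0.05 log units; within the scatter). Adding one ring carbon at this place therefore does not move the number on this core, which the earlier compounds could not show. The open-chain diethylamino group is now set apart from two rings rather than one, with an 8.3-fold higher number from compound 1 to compound 4 (0.92 log units; beyond the scatter) closely matching the earlier 9.3-fold higher number from compound 1 to compound 3 (0.97 log units; beyond the scatter), so on this core the clear shift goes with replacing diethylamino by either ring, and ring size plays no visible part; no supporting information is available on why the open-chain group and the rings differ.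

The compounds shown leave open whether a ring holding a second hetero atom, such as morpholine, would stay with the two rings or move towards diethylamino. They also do not show where a smaller open-chain amine, such as dimethylamino, would fall, or whether the same pattern would hold on the core of compound 2.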